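Methoxy for fluoro on the pyrazoline aryl group

A few compounds are considered here, and "the series" means these few. Any claim that something is new, unique, unknown or untested is made for them only; others in the source may bear on it.

Measured compounds:
compound 1, `COc1ccc(C2=NN(C(=O)c3ccc4c(c3)OCCO4)C(c3ccc(F)cc3)C2)cc1`: 3780 nM
compound 2, `O=C(c1ccc2c(c1)OCCO2)N1N=C(c2ccccc2)CC1c1ccc(F)cc1`: 5210 nM
compound 3, `O=C(C1COc2ccccc2O1)N1N=C(c2ccccc2)CC1c1ccc(F)cc1`: 3270 nM

Three compounds on a shared core were tested in a functional assay on WM 266-4 cells (Homo sapiens) for inhibition, read by MTT assay, with a stated time of 24 h; a higher number here means a weaker inhibitor of growth, a lower number a stronger inhibitor of growth. Compound 2 gives the highest of the three numbers, with 5210 nM; its nearest neighbour is compound 1 at 3780 nM and the furthest is compound 3 at 3270 nM, and both gaps lie within the scatter of this assay.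

The step to compound 4, `COc1ccc(C2CC(c3ccccc3)=NN2C(=O)c2ccc3c(c2)OCCO3)cc1`, is methoxy in place of fluoro on an aromatic carbon, on the aryl group sitting on the saturated carbon of the core. Among the measured compounds shown here, no measured step changes this position. The nearest comparison is the removal of a methoxy from the other aryl ring, which gave a 1.4-fold higher number from compound 1 to compound 2 (0.14 log units; within the scatter), and the change of the carbonyl substituent gave a 1.6-fold lower number from compound 2 to compound 3 (0.20 log units; within the scatter); both lie within the scatter. Small substituent changes on this core have so far moved the number little, so no step beyond the scatter is expected for compound 4.

Compound 4 is therefore estimated at 4200 nM in this assay, within a range of 1500 nM to 11000 nM, which corresponds to an expected step of a 1.2-fold lower number from compound 2 to compound 4 (0.09 log units; within the scatter).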

Compound 4, concentration for 50% growth inhibition: 8370 nM
Compound 4: the middle estimate sits 2.0-fold (0.30 log units) below what was measured, and the stated range covers the measured number.
By their numbers in this assay, from the lowest: compounds 3, 1, 2 and 4 (each within the scatter of the next, the first and the last beyond it).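

Among the compounds shown here, the exchange of 4-fluorophenyl for 4-methoxyphenyl gives the first reading at this position: in this assay it amounts to a 1.6-fold higher number from compound 2 to compound 4 (0.21 log units; within the scatter). On this one pair, the position accepts methoxy, with its added heavy atom and hydrogen-bond acceptor, without a step beyond the scatter, so the step is no evidence that the change matters for growth inhibition. Nothing available explains the step or links it to any property of the methoxy group.

From the compounds shown here alone, what an amine, a carboxylic acid or a longer alkoxy chain would do in place of the fluoro remains open. Also open, going by these compounds, is how 4-methoxyphenyl would behave when combined with the changes seen in compound 1 or compound 3.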